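This account rests on a few compounds, and the source may have more. Where it says the series, first, only, none or still open, it means among the compounds named here.

Compound 2 `Cc1ccc(-n2cc(CN3C(=O)C[C@@H]4CC[C@@]3(C)C4(C)C)nn2)cc1`, a bornane-derived lactam carrying a triazole linked to a 4-methylphenyl group, is the weakest inhibitor among the three measured compounds in a functional assay on HepG2 cells (Homo sapiens) for inhibition, read by MTT assay, with a stated time of 24 h (on this read-out higher numbers stand for weaker inhibition and lower numbers for stronger inhibition), where compound 2 gives 480 nM. Compound 1 `CC1(C)[C@H]2CC[C@]1(C)N(Cc1cn(-c3ccccc3O)nn1)C(=O)C2` gives 120 nM, and compound 3 `CC1(C)[C@H]2CC[C@]1(C)N(Cc1cn(-c3ccc(F)cc3)nn1)C(=O)C2` gives 90 nM in this assay. Compound 4 `CC1(C)[C@H]2CC[C@]1(C)N(Cc1cn(-c3cccc(O)c3)nn1)C(=O)C2` is not yet measured; it differs from compound 2 in that (3-hydroxyphenyl in place of 4-methylphenyl on an aromatic nitrogen).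

Going by the values given here, two measured steps bear on this change. Going from a 2-hydroxyphenyl to a 4-methylphenyl, the number rose a 4.0-fold higher number from compound 1 to compound 2 (0.60 log units; beyond the scatter), and swapping the methyl for a fluoro lowered it a 5.3-fold lower number from compound 2 to compound 3 (0.73 log units; beyond the scatter). Both steps say that the 4-methylphenyl of compound 2 is the least favourable of the aryl groups tried, and that a hydroxyphenyl group is tolerated well. A modest lowering of the number in this assay is therefore expected for compound 4, so a step of a 3.2-fold lower number from compound 2 to compound 4 (0.51 log units; beyond the scatter) is estimated. Compound 4 is expected to give 150 nM, within a range from 60 nM to 400 nM.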

Compound 4, half-maximal inhibitory concentration: 70 nM
Compound 4: middle estimate off by 2.1-fold (0.33 log units), on the high side; low and high end bracket the measured number.
By their numbers in this assay, from the lowest: compounds 4, 3 and 1 (each within the scatter of the next); then compound 2.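

In this assay, 3-hydroxyphenyl in place of 4-methylphenyl gives a 6.9-fold lower number from compound 2 to compound 4 (0.84 log units; beyond the scatter), so this position on the aromatic nitrogen responds clearly to this change. The hydroxyl-bearing ring gives a similar result in two forms, as 2-hydroxyphenyl and 3-hydroxyphenyl cannot be told apart in a 1.7-fold lower number from compound 1 to compound 4 (0.23 log units; within the scatter), and 4-fluorophenyl cannot be told apart from 3-hydroxyphenyl in a 1.3-fold lower number from compound 3 to compound 4 (0.11 log units; within the scatter). Compound 2 therefore stands alone, while compounds 1, 3 and 4 form one group, and no supporting data explain this difference.

On these data alone, it remains open how 4-hydroxyphenyl, aminophenyl or carboxyphenyl would behave at this position. As far as these compounds go, it is also open whether an unsubstituted phenyl would fall with compound 2 or with the other three compounds.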